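Notes on the benzyl amide step to compound 4

A few compounds are considered here, and "the series" means these few. Any claim that something is new, unique, unknown or untested is made for them only; others in the source may bear on it.

In an ADME assay on J774.A1 cells (Mus musculus) for cytotoxicity, read by MTT assay, with a stated time of 48 h (on this read-out higher numbers stand for lower toxicity in this test and lower numbers for higher toxicity in this test), compound 1 (`COC(=O)c1c([N+](=O)[O-])noc1-c1ccc(Cl)cc1Cl`) reads 19700 nM while compound 2 (`O=C(Nc1ccccc1)c1c([N+](=O)[O-])noc1-c1ccc(Cl)cc1Cl`) reads 67300 nM and compound 3 (`COc1ccc(CNC(=O)c2c([N+](=O)[O-])noc2-c2ccc(Cl)cc2Cl)cc1`) reads 80500 nM on the same scale. Compound 3 and compound 2 lie within the scatter of each other, and compound 1 sits beyond the scatter on the lower side of compound 3.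

Compound 4 (`O=C(NCc1cccc(Br)c1)c1c([N+](=O)[O-])noc1-c1ccc(Cl)cc1Cl`) carries 3-bromophenyl in place of 4-methoxyphenyl on a saturated chain carbon bound to an amide-type nitrogen. Anilino in place of methoxy on the carbonyl carbon gave a modest move (a 3.4-fold higher number from compound 1 to compound 2 (0.53 log units; beyond the scatter)) but at a different place. The nearer precedent is 4-methoxybenzyl in place of phenyl on the amide-type nitrogen (a 1.2-fold higher number from compound 2 to compound 3 (0.08 log units; within the scatter)) which stayed within the scatter, so no step beyond the scatter is expected in this assay for compound 4. Going by the values given here, no measured compound carries bromine, so that group remains untested here. The estimated step is small (a 1.2-fold lower number from compound 3 to compound 4 (0.09 log units; within the scatter)) and stays within the scatter. Compound 4 is estimated at 65000 nM with 28000 nM to 140000 nM as its range.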

Compound 4, half-maximal cytotoxic concentration: 71200 nM
The estimate for compound 4 lay 1.1-fold (0.04 log units) below the measured number, and the stated range covers the measured number.
By their numbers in this assay, from the lowest: compound 1; then compounds 2, 4 and 3 (each within the scatter of the next).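

In this assay, 3-bromophenyl in place of 4-methoxyphenyl on a saturated chain carbon bound to an amide-type nitrogen gives (a 1.1-fold lower number from compound 3 to compound 4 (0.05 log units; within the scatter)), so this place accepts a different ring substituent, here bromine for methoxy, without a step beyond the scatter. The comparison with the anilide gives (a 1.1-fold higher number from compound 2 to compound 4 (0.02 log units; within the scatter)), while the comparison with the ester gives (a 3.6-fold higher number from compound 1 to compound 4 (0.56 log units; beyond the scatter)), so among the compounds shown only replacing the ester methoxy with an amine-derived group moves the number beyond the scatter. Nothing available explains why this ring change leaves the number within the scatter.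

An amine or a carboxylic acid in place of the bromine, or a longer chain on the amide-type nitrogen, lies outside the compounds shown. Going by these compounds, whether such groups would give a step beyond the scatter at this place remains open.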